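The source may report more compounds than this note shows. Statements on the series, on what has been measured and on what is new or still open speak of the compounds shown alone.

Measured compounds:
Compound 1 `COc1ccc(/C=C2\CN(C)CC3=C2N=C(S)NC3c2ccc(OC)cc2)cc1` gives 76300 nM in a functional assay (Homo sapiens) for inhibition; a higher number here means a weaker inhibitor of growth, a lower number a stronger inhibitor of growth.
Compound 2 `CN1C/C(=C\c2cccs2)C2=NN(C)C(c3cccs3)C2C1` gives > 100000 nM in this assay; this is a limit of the assay, not a number.

Compound 1 is the only one of the two with a numerical value, and that value marks it as a weak inhibitor of growth. Compound 2 stands at the limit of > 100000 nM in this assay, at which 1 of the 2 values shown sits, so the two measured compounds cannot be ordered against each other beyond saying that neither inhibits growth strongly. For the measured compounds named here, no step between measured compounds is known for this pair of structures.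

Compound 3 `CN1C/C(=C\c2cccs2)C2=NN(c3ccccc3)C(c3cccs3)C2C1` is the next compound to be measured. It differs from compound 2 by phenyl in place of methyl on an amine nitrogen in a ring. Since compound 2 only gives a limit, the size of the step in this assay cannot be anchored to a number; the expectation is a small change, if any, with the value of compound 3 still in the weak range and a fair chance that the assay again reports only a limit. The step from compound 2 to compound 3 is expected to be an at least 1.2-fold lower number from compound 2 to compound 3 (0.09 log units; that floor lies within the scatter). Compound 3 is estimated at 80000 nM, in the range 30000 nM to 200000 nM.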

Compound 3, concentration for total growth inhibition: 87100 nM
Compound 3: the middle estimate sits 1.1-fold (0.04 log units) below what was measured; the range from low to high includes it.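

With phenyl in place of methyl on an amine nitrogen in a ring, the compounds show an at least 1.1-fold lower number from compound 2 to compound 3 (0.05 log units; that floor lies within the scatter) in this assay. For the compounds shown here, this is the first sign that this nitrogen, next to the ring atom that bears a thiophen-2-yl group, can carry a six-membered aromatic ring while the read-out still gives a number, with compound 3 at 87100 nM, still a weak inhibitor of growth. Compound 2 gives > 100000 nM, which is a limit of the assay and not a number, so only a floor for the step can be read, and that floor does not go beyond the usual scatter: the limit of > 100000 nM in this assay, at which 1 of the 3 values shown sits.

From the compounds shown here alone, whether phenyl truly differs from methyl at this nitrogen therefore stays open, and so does the question of what an intermediate group such as ethyl or benzyl would give in this assay. The compounds shown also leave open whether a methoxy group, an amine or a carboxylic acid on the new phenyl ring would move the number towards stronger inhibition of growth.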